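A few compounds are considered here, and "the series" means these few. Any claim that something is new, unique, unknown or untested is made for them only; others in the source may bear on it.

Compound 1 `COc1ccc(-c2c(Cl)c(=O)c3c(OC)cc(OC)cc3n2S(=O)(=O)c2ccc(OC)cc2)cc1` gives 17900 nM in a functional assay on SUP-B15 cells (Homo sapiens) for antiproliferative activity, with a stated time of 72 h; a higher number here means that more compound is needed for the effect, a lower number that less compound is needed.
Compound 2 `COc1ccc(-c2c(Br)c(=O)c3c(OC)cc(OC)cc3n2S(=O)(=O)c2ccc(OC)cc2)cc1` gives 2920 nM in this assay.
Compound 3 `COc1ccc(-c2[nH]c3cc(OC)cc(OC)c3c(=O)c2I)cc1` gives > 86200 nM in this assay.

For compound 3 the value is a limit of the assay and not a number (the limit of > 86200 nM in this assay, at which 1 of the 3 values shown sits). Compound 4 `COc1ccc(-c2c(I)c(=O)c3c(OC)cc(OC)cc3n2S(=O)(=O)c2ccc(OC)cc2)cc1` differs from compound 3 in one place: (4-methoxyphenyl)sulfonyl in place of hydrogen on an aromatic nitrogen. Among the compounds with values here, the only measured step, a 6.1-fold lower number from compound 1 to compound 2 (0.79 log units; beyond the scatter), concerns a different change and does not bear on this one. Compounds 1 and 2, which both carry the same sulfonyl group that enters here, give numbers within the assay rather than limits. On that basis compound 4 is expected to move from the limit to a measurable number, a step of roughly an at least 21-fold lower number from compound 3 to compound 4 (1.33 log units; beyond the scatter). The estimate for compound 4 in this assay is 4000 nM, with a range from 600 nM to 40000 nM.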

Compound 4, half-maximal effective concentration: 12300 nM
For compound 4 the middle estimate is 3.1-fold (0.49 log units) below the measured one, within the range that was stated.
By their numbers in this assay, from the lowest: compound 2; then compounds 4 and 1 (each within the scatter of the next). At a limit, above all of these: compound 3.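

The value of compound 3 is a limit and not a number: the limit of > 86200 nM in this assay, at which 1 of the 4 values shown sits.
As far as these compounds go, with iodo on the shared core, (4-methoxyphenyl)sulfonyl in place of hydrogen on an aromatic nitrogen gives an at least 7.0-fold lower number from compound 3 to compound 4 (0.84 log units; beyond the scatter), so the true size of this change stays unknown, though it is beyond the scatter. The halogen series is also not a steady trend: iodo in place of bromo gives a 4.2-fold higher number from compound 2 to compound 4 (0.62 log units; beyond the scatter), while iodo in place of chloro gives a 1.5-fold lower number from compound 1 to compound 4 (0.16 log units; within the scatter), leaving bromo apart from the other two.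

From the compounds shown here alone, whether fluoro would behave like bromo or like chloro and iodo remains open. So does whether an amine or a carboxylic acid in place of the methoxy on the sulfonyl group would keep a measurable number.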